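Methyl in place of chloro: the step to compound 4

This account rests on a few compounds, and the source may have more. Where it says the series, first, only, none or still open, it means among the compounds named here.

Of the compounds shown here, three sharing one core have been measured in a functional assay on PC-3 cells (Homo sapiens) for inhibition, read by MTT assay, with a stated time of 72 h; on this read-out higher numbers stand for weaker inhibition and lower numbers for stronger inhibition. Compound 1 `C=CC(=O)Nc1cccc(NC(=O)CSc2nc(Nc3ccccc3Br)c3ccccc3n2)c1` gives 17100 nM, compound 2 `C=CC(=O)Nc1cccc(NC(=O)CSc2nc(Nc3cccc(F)c3)c3ccccc3n2)c1` gives 5370 nM, and compound 3 `C=CC(=O)Nc1cccc(NC(=O)CSc2nc(Nc3cccc(Cl)c3)c3ccccc3n2)c1` gives 12300 nM, the second highest of the three numbers. The step of a 1.4-fold lower number from compound 1 to compound 3 (0.14 log units; within the scatter) lies within the scatter, whereas the step of a 2.3-fold higher number from compound 2 to compound 3 (0.36 log units; beyond the scatter) is modest but beyond it.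

Compound 4 `C=CC(=O)Nc1cccc(NC(=O)CSc2nc(Nc3cccc(C)c3)c3ccccc3n2)c1` differs from compound 3 in one place: methyl in place of chloro on an aromatic carbon. Going by the values given here, no measured step exchanges chloro for methyl, so the only guidance is the exchange of fluoro for chloro at the same place, which moved the number modestly. A single-atom swap of this kind is therefore expected to give, for compound 4, a step of a 1.2-fold lower number from compound 3 to compound 4 (0.09 log units; within the scatter) that does not pass beyond the scatter. The estimate for compound 4 in this assay is 10000 nM, with a range from 4000 nM to 25000 nM.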

Compound 4, half-maximal inhibitory concentration: 29200 nM
For compound 4 the middle estimate is 2.9-fold (0.47 log units) below the measured one; measured number above the stated range.
By their numbers in this assay, from the lowest: compound 2; then compounds 3, 1 and 4 (each within the scatter of the next, the first and the last beyond it).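

The exchange of chloro for methyl at this place is not neutral in this assay (a 2.4-fold higher number from compound 3 to compound 4 (0.38 log units; beyond the scatter)), and it moves the number in the same direction as the earlier exchange of fluoro for chloro. Among these three groups on the same aromatic carbon, the numbers therefore rise from fluoro through chloro to methyl, with the full span set by the fluoro to methyl exchange (a 5.4-fold higher number from compound 2 to compound 4 (0.74 log units; beyond the scatter)), while 3-methylphenyl and 2-bromophenyl cannot be told apart (a 1.7-fold higher number from compound 1 to compound 4 (0.23 log units; within the scatter)). Nothing available here accounts for this order.

On these data alone, whether the order extends to other groups at this place, such as methoxy, an amine or trifluoromethyl, remains open. As far as these compounds go, it is also open whether the chloro to methyl step would keep its size on a different part of the shared core.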